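The compounds below may be only part of what the source reports. "The series", "measured", "known", "first", "only" and "open" are said of these compounds alone.

Values in a functional assay on A549 cells (Homo sapiens) for cytotoxicity, read by sulforhodamine B assay; a lower number here means a stronger inhibitor, a higher number a weaker inhibitor:
- Compound 1 `C=C1[C@@H](OC(C)=O)C[C@@H]2[C@](C)(CO[Si](C)(C)C(C)(C)C)[C@H](OC(C)=O)CC[C@@]2(C)[C@@H]1C[C@@H](Nc1ccc(OC)c(OC)c1)C1=CCOC1=O`: 4870 nM
- Compound 2 `C=C1CC[C@@H]2[C@](C)(CO[Si](C)(C)C(C)(C)C)[C@H](OC(C)=O)CC[C@@]2(C)[C@@H]1C/C=C1/C(=O)OC[C@H]1OC(C)=O`: 3990 nM
- Compound 3 `C=C1[C@@H](OC(C)=O)C[C@@H]2[C@](C)(COC=O)[C@H](OC(C)=O)CC[C@@]2(C)[C@@H]1C[C@@H](Nc1ccc(OC)c(OC)c1)C1=CCOC1=O`: > 50000 nM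

In this assay compound 1 gives 4870 nM and compound 2 gives 3990 nM, two values within the scatter of each other. Compound 3 reports only a limit, > 50000 nM.

Compound 4 `C=C1[C@@H](OC(C)=O)C[C@@H]2[C@](C)(CO[Si](C)(C)C(C)(C)C)[C@H](OC(C)=O)CC[C@@]2(C)[C@@H]1C[C@@H](Nc1ccccc1)C1=CCOC1=O` differs from compound 1 as follows: phenyl in place of 3,4-dimethoxyphenyl on an amine nitrogen. In short, phenyl replaces 3,4-dimethoxyphenyl on an amine nitrogen. Within the data shown here, no measured step changes this group. Among the measured compounds shown here, the one measured step, an at least 10-fold higher number from compound 1 to compound 3 (1.01 log units; beyond the scatter), is large, but it lies elsewhere, on an oxygen on a saturated carbon, and compound 3 keeps the 3,4-dimethoxyphenyl. It therefore says little about this change. Compound 2 carries no such amine and gives 3990 nM, so a change on the amine is not expected to move the number far. The expected step is a 1.0-fold higher number from compound 1 to compound 4 (0.01 log units; within the scatter), which is no change beyond the scatter. For compound 4 the estimated value is 5000 nM, with an expected range from 2200 nM to 12000 nM.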

Compound 4, half-maximal inhibitory concentration: 4500 nM
Estimate against measurement, compound 4: 1.1-fold (0.05 log units) above, within the range that was stated.
By their numbers in this assay, from the lowest: compounds 2, 4 and 1 (each within the scatter of the next). At a limit, above all of these: compound 3.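

In this assay, among these compounds, the first measured step on the amine nitrogen reads a 1.1-fold lower number from compound 1 to compound 4 (0.03 log units; within the scatter), so at this position phenyl and 3,4-dimethoxyphenyl cannot be told apart, and the aromatic ring without its two oxygens still gives a number of the same size as compound 1. The only step shown beyond the scatter remains an at least 10-fold higher number from compound 1 to compound 3 (1.01 log units; beyond the scatter), which lies elsewhere, on an oxygen on a saturated carbon, so the amine position and that oxygen now read differently in this series of compounds. Nothing measured here speaks to why the change on the amine nitrogen leaves the number in place.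

Open, as far as these compounds go, is whether a carboxylic acid or an amine on the phenyl ring, or a cyclohexyl group in place of the phenyl on the amine nitrogen, would move the number beyond the scatter. Also open, from the compounds shown here alone, is whether phenyl would read the same way in a compound carrying the group that compound 3 has on that oxygen.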